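The source may report more compounds than this note shows. Statements on the series, on what has been measured and on what is new or still open speak of the compounds shown alone.

Compound 1 `COc1cc(C(=O)NNC(=S)Nc2csc(-c3ccccc3)c2)cc(OC)c1OC` — 55000 nM
Compound 2 `COc1cc(C(=O)NNC(=S)Nc2csc(-c3ccc(C)cc3)c2)cc(OC)c1OC` — 42000 nM
Compound 3 `COc1cc(OC)cc(C(=O)NNC(=S)Nc2csc(-c3ccccc3)c2)c1` — 37000 nM

All three compounds were tested in a functional assay on SK-MEL-28 cells (Homo sapiens) for inhibition, read by colorimetric assay and MTT assay, with a stated time of 72 h; a lower number here means a stronger inhibitor, a higher number a weaker inhibitor. On the numbers shown, compound 3 stands with the smallest value, yet its gaps to compound 2 and to compound 1 both fall within the usual scatter, so the three cannot be told apart on this evidence.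

Compound 4 `COc1cc(OC)cc(C(=O)NNC(=S)Nc2csc(-c3ccc(C)cc3)c2)c1` differs from compound 3 in one place: methyl in place of hydrogen on an aromatic carbon. The same change has been measured once before, between compound 1 and compound 2, where it gave a 1.3-fold lower number from compound 1 to compound 2 (0.12 log units; within the scatter). The other measured step, a 1.5-fold lower number from compound 1 to compound 3 (0.17 log units; within the scatter), concerns a different change and so speaks to this one only indirectly. With one precedent that stayed within the scatter, the step into compound 4 is expected to be small and of no clear direction.

Compound 4 is therefore estimated at 30000 nM in this assay, with a range from 15000 nM to 60000 nM. This estimate amounts to a step of a 1.2-fold lower number from compound 3 to compound 4 (0.09 log units; within the scatter), which is expected to stay within the scatter.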

Compound 4, half-maximal inhibitory concentration: 38000 nM
Compound 4: middle estimate off by 1.3-fold (0.10 log units), on the low side, and the stated range covers the measured number.
By their numbers in this assay, from the lowest: compounds 3, 4, 2 and 1 (each within the scatter of the next).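

In this assay, the change from phenyl to 4-methylphenyl now has a second reading, a 1.0-fold higher number from compound 3 to compound 4 (0.01 log units; within the scatter), and it agrees with the first: the same change on two cores in this assay, a 1.3-fold lower number (0.12 log units; within the scatter) from compound 1 to compound 2 and a 1.0-fold higher number (0.01 log units; within the scatter) from compound 3 to compound 4, 1.3-fold (0.13 log units) apart, within the scatter of two such steps Hydrogen in place of methoxy also has a second reading, a 1.1-fold lower number from compound 2 to compound 4 (0.04 log units; within the scatter), which agrees with its first in the same way: the same change on two cores in this assay, a 1.5-fold lower number (0.17 log units; within the scatter) from compound 1 to compound 3 and a 1.1-fold lower number (0.04 log units; within the scatter) from compound 2 to compound 4, 1.3-fold (0.13 log units) apart, within the scatter of two such steps Each change has therefore stayed within the scatter on both cores, and neither shows a clear direction.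

At the place para to a large group, only hydrogen and methyl are shown, so these compounds cannot tell whether a longer chain, an amine or a carboxylic acid there would move the number beyond the scatter. As far as these compounds go, whether any group at this place gives a clearly stronger inhibitor remains open.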